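A few compounds are considered here, and "the series" means these few. Any claim that something is new, unique, unknown or untested is made for them only; others in the source may bear on it.

Measured in an ADME assay on Raji cells (Homo sapiens) for cytotoxicity, read by luminescence, with a stated time of 72 h; on this read-out lower numbers stand for an effect already at smaller amounts and higher numbers for an effect only at larger amounts of compound:
- Compound 1 `CCOC(=O)c1c(-c2cccc(OCc3ccccc3)c2)[nH]c2cc(OC)ccc2c1=O` gives the limit > 21500 nM.
- Compound 2 `CCOC(=O)c1c(-c2cccc(Oc3ccccc3)c2)[nH]c2cc(OC)ccc2c1=O` gives the limit > 21500 nM.
- Compound 3 `CCOC(=O)c1c(-c2cccc(NC(C)=O)c2)[nH]c2cc(OC)ccc2c1=O` gives the limit > 21500 nM.

Compound 2 therefore has no exact number, and neither of the other two compounds offers one for comparison. Compound 4 `CCOC(=O)c1c(-c2cccc(Oc3ccccc3)c2)[nH]c2cc(OC)c(OC)cc2c1=O` carries methoxy in place of hydrogen on an aromatic carbon of compound 2, ortho to the methoxy group already present: methoxy in place of hydrogen on an aromatic carbon. The measured steps are a step that the two limits leave unreadable from compound 1 to compound 2, a step that the two limits leave unreadable from compound 1 to compound 3 and a step that the two limits leave unreadable from compound 2 to compound 3. All three end at one shared limit, as the limit of > 21500 nM in this assay, at which 3 of the 3 values shown sit, shows, so they give no size, and none of them changes this part of the core. With nothing pointing either way, the expected step that the limit leaves unreadable from compound 2 to compound 4 is no larger than the usual scatter, with no direction foreseen. For compound 4 the estimated value is 30000 nM, with an expected range of 12000 nM to 60000 nM.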

Compound 4, half-maximal effective concentration: > 21500 nM
Compound 4 gave a limit, no number (the forecaster's own chance of this, stated with the estimate: 85%); the middle value does not contradict the limit.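

Among these compounds, compound 2 and compound 4 both end at a limit rather than a number, so no step between them can be read: the limit of > 21500 nM in this assay, at which 4 of the 4 values shown sit. The compounds shown leave open whether methoxy in place of hydrogen, or any other change among them, alters the result in this assay.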